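Ring-opened amine substituent on the piperidine of compound 3

The compounds below may be only part of what the source reports. "The series", "measured", "known", "first", "only" and "open" are said of these compounds alone.

Measured so far:
compound 1, `Cc1ncccc1-c1nc2cn(-c3ccccc3)nc2c(=O)n1C[C@H]1CCCN(C[C@H]2CCCO2)C1`, in an assay on HEK293 cells for displacement of a labelled ligand from growth hormone secretagogue receptor type 1 (Homo sapiens), with a stated time of 60 min (on this read-out lower numbers stand for stronger inhibition and higher numbers for weaker inhibition), gives 190 nM
compound 2, `COc1ccc(-n2cc3nc(-c4ccccc4C)n(CC4CCCN(C(C)C)C4)c(=O)c3n2)cc1`, in this assay gives 7.3 nM
compound 3, `COc1cccc(-n2cc3nc(-c4cccnc4C)n(C[C@H]4CCCN(CC5CCOC5)C4)c(=O)c3n2)c1`, in this assay gives 60 nM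

Compound 3 holds the second-highest of the three numbers. Its nearest neighbour is compound 1, whose number lies higher, and its furthest is compound 2, whose number lies lower; both gaps fall beyond the usual scatter. None of these three pairs differs in a single place, so no step can be read from them.

Compound 4, `CCO[C@@H](C)CN1CCC[C@H](Cn2c(-c3cccnc3C)nc3cn(-c4cccc(OC)c4)nc3c2=O)C1`, differs from compound 3 in one place: 1-ethoxyethyl in place of oxolan-3-yl on a saturated chain carbon bound to an amine nitrogen in a ring. A ring gives way to a chain and a defined stereocentre enters; the rest of the molecule is unchanged.

Among the compounds with values here, no measured pair in this set isolates such a change, so the expectation rests on the similarity of the leaving and entering groups. The step in this assay is estimated as a 1.2-fold higher number from compound 3 to compound 4 (0.07 log units; within the scatter), within the scatter in either direction. Compound 4 is expected to give 70 nM, with a range from 25 nM to 200 nM.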

Compound 4, half-maximal inhibitory concentration: 5 nM
Beside the measured number, compound 4's estimate is 14-fold (1.15 log units) above it; measured number outside the range, below it.
By their numbers in this assay, from the lowest: compounds 4 and 2 (each within the scatter of the next); then compound 3; then compound 1.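

In this assay, 1-ethoxyethyl in place of oxolan-3-yl on a saturated chain carbon bound to an amine nitrogen in a ring gives a 12-fold lower number from compound 3 to compound 4 (1.08 log units; beyond the scatter) and so shows that this position is sensitive, even to a swap that keeps the heavy-atom count, the oxygen and the hydrogen-bond acceptor count unchanged. The earlier compounds shown here differed from one another in several places at once, so none could tie a change in number to this substituent alone. Nothing at hand accounts for the size of this step.

Going by these compounds, whether the loss of the ring or the defined stereocentre carries the step remains open, as does the effect of the opposite configuration at that stereocentre. On these data alone, it is also open whether 1-methoxyethyl or 1-propoxyethyl at this place would behave like 1-ethoxyethyl.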